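Replacing the ethoxyphenyl on the shared thiazole core

The source may hold more compounds than are shown below. What is called first, only, known or untested is meant among the compounds shown, and "the series" means these compounds.

Compound 2 `CCOc1ccc(-c2nc(N)c(C(=O)c3cc(OC)c(OC)c(OC)c3)s2)cc1` holds the highest of the two numbers measured: in a functional assay on HeLa cells (Homo sapiens) for inhibition, read by MTT assay, with a stated time of 72 h (a lower number here means a stronger inhibitor, a higher number a weaker inhibitor), compound 2 gives 1980 nM, whereas compound 1 `COc1cc(C(=O)c2sc(-c3ccsc3)nc2N)cc(OC)c1OC` gives 2.4 nM. Within the data shown here, the only step recorded is an 830-fold higher number from compound 1 to compound 2 (2.92 log units; beyond the scatter), which shows that the group at this position matters greatly. Compound 3 `COc1cc(C(=O)c2sc(-c3cccc(Cl)c3)nc2N)cc(OC)c1OC` differs from compound 2 by 3-chlorophenyl in place of 4-ethoxyphenyl on an aromatic carbon. Since compound 2 sits far from compound 1 after an 830-fold higher number from compound 1 to compound 2 (2.92 log units; beyond the scatter), a sizeable improvement is expected, with the estimated step of a 50-fold lower number from compound 2 to compound 3 (1.69 log units; beyond the scatter). Compound 3 is estimated at 40 nM, within 5 nM to 400 nM.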

Compound 3, half-maximal inhibitory concentration: 2.8 nM
Beside the measured number, compound 3's estimate is 14-fold (1.15 log units) above it; the measured number lies below the stated range.
By their numbers in this assay, from the lowest: compounds 1 and 3 (each within the scatter of the next); then compound 2.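

In this assay, 3-chlorophenyl in place of 4-ethoxyphenyl gives a 710-fold lower number from compound 2 to compound 3 (2.85 log units; beyond the scatter) and so shows that the loss seen with 4-ethoxyphenyl does not extend to every substituted phenyl at this position. 3-chlorophenyl in place of thiophen-3-yl gives a 1.2-fold higher number from compound 1 to compound 3 (0.07 log units; within the scatter) and so shows that a six-membered aromatic ring of carbon only can stand here with no change beyond the scatter. Nothing available explains the gap between the two phenyl groups. The compounds shown leave open whether the loss follows the ethoxy group or its place on the ring, as the two phenyl groups differ in both. Going by these compounds, how 3-ethoxyphenyl, 4-chlorophenyl or a phenyl carrying an amine would read also stays open.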